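This account rests on a few compounds, and the source may have more. Where it says the series, first, only, none or still open, it means among the compounds named here.

Measured compounds:

- Compound 1, `O=C(NCCCCCCS)c1cc(-c2ccc3ccccc3c2)n[nH]1`, gives 235 nM in an assay on isolated protein for inhibition of protein deacetylase HDAC6 (Homo sapiens), read by fluorescence, with stated times of 15 min and 60 min; on this read-out lower numbers stand for stronger inhibition and higher numbers for weaker inhibition
- Compound 2, `O=C(NCCCCCCS)c1cc(C2CCCCC2)n[nH]1`, gives 241 nM in this assay
- Compound 3, `O=C(NCCCCCCS)c1cc(-c2cccc3ccccc23)n[nH]1`, gives 244 nM in this assay

All three share the same core and the same thiol-bearing chain on the amide, and differ only in the group attached to the five-membered aromatic ring. Compound 2 carries a cyclohexyl there; its number sits in the middle of the three, and the values of compound 1 and compound 3 both lie within the usual scatter of it, so the three compounds cannot be told apart on this read-out.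

Compound 4, `O=C(NCCCCCCS)c1cc(-c2cnccn2)n[nH]1`, has not yet been measured in this assay. It differs from compound 2 in one place: pyrazin-2-yl in place of cyclohexyl on an aromatic carbon.

Within the data shown here, no comparison between measured compounds is available, so the expected step rests on the observation that a naphthyl and a cyclohexyl at this position give the same number. On that basis compound 4 is expected to stay close to compound 2, with a step of a 1.2-fold higher number from compound 2 to compound 4 (0.10 log units; within the scatter) that is not expected to go beyond the scatter. The estimated value for compound 4 in this assay is 300 nM, with a range from 120 nM to 900 nM.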

Compound 4, half-maximal inhibitory concentration: 22 nM
The estimate for compound 4 lay 14-fold (1.13 log units) above the measured number, outside the stated range (below it).
By their numbers in this assay, from the lowest: compound 4; then compounds 1, 2 and 3 (each within the scatter of the next).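

In this assay the group on this aromatic carbon clearly matters: the cyclohexyl and naphthyl compounds could not be told apart, yet pyrazin-2-yl in place of cyclohexyl gives an 11-fold lower number from compound 2 to compound 4 (1.04 log units; beyond the scatter) on the same core. The two groups match in heavy-atom count and are both six-membered rings, so the swap replaces a non-aromatic ring of carbon only with an aromatic ring that holds nitrogen atoms and hydrogen-bond acceptors. Nothing measured here explains why this swap gives such a large step.

The compounds shown leave open whether the ring nitrogens are needed at all, and how many, which a phenyl or a pyridin-2-yl at this place could help to settle. As far as these compounds go, it also remains open whether the pyrazin-2-yl keeps its advantage with a shorter chain carrying the thiol.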